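This account rests on a few compounds, and the source may have more. Where it says the series, first, only, none or still open, it means among the compounds named here.

Compound 3 `COc1ccccc1N1CCN(CCCCC(=O)NCc2ccccc2-c2cccc(Cl)c2)CC1` gives 405 nM in an assay on CHO-K1 cells for displacement of a labelled ligand from 5-hydroxytryptamine receptor 7 (Homo sapiens), read by scintillation counting (a lower number here means a stronger inhibitor, a higher number a weaker inhibitor), the highest of the three numbers: compound 1 `COc1ccccc1N1CCN(CCCCC(=O)NCc2ccccc2-c2c(OC)cccc2OC)CC1` gives 32.4 nM and compound 2 `COc1ccccc1N1CCN(CCCCC(=O)NCc2ccccc2-c2ccccc2C)CC1` gives 26.1 nM, so the steps of a 13-fold higher number from compound 1 to compound 3 (1.10 log units; beyond the scatter) and a 16-fold higher number from compound 2 to compound 3 (1.19 log units; beyond the scatter) are both large. Compound 4 `COc1ccccc1N1CCN(CCCCC(=O)NCc2ccccc2-c2ccccc2)CC1` differs from compound 3 by hydrogen in place of chloro on an aromatic carbon. Within the data shown here, no measured step removes a chloro on its own; the two steps that end at compound 3 swap the whole substituted ring, so they bear only loosely on this change and set no clear direction. A moderate step of a 2.7-fold lower number from compound 3 to compound 4 (0.43 log units; beyond the scatter) towards a lower number is therefore expected, with wide uncertainty. Compound 4 is estimated at 150 nM, between 50 nM and 500 nM.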

Compound 4, inhibition constant: 37.9 nM
Compound 4: middle estimate off by 4.0-fold (0.60 log units), on the high side; the measured number lies below the stated range.
By their numbers in this assay, from the lowest: compounds 2, 1 and 4 (each within the scatter of the next); then compound 3.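

Among these compounds, with hydrogen in place of chloro on this aromatic carbon, meta to a large group, the single change gives an 11-fold lower number from compound 3 to compound 4 (1.03 log units; beyond the scatter) in this assay. The phenyl of compound 4 stays within the scatter of the substituted rings, with a 1.5-fold higher number from compound 2 to compound 4 (0.16 log units; within the scatter) and a 1.2-fold higher number from compound 1 to compound 4 (0.07 log units; within the scatter) in the same assay, so among these four compounds only the 3-chlorophenyl stands apart. Nothing here offers a reason for the chloro step.

Chloro is the only group shown at this position, so it stays open whether fluoro, methyl or an amine there would go with chloro or with hydrogen.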